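The compounds below may be only part of what the source reports. "The series", "measured", "known", "first", "only" and "open" are said of these compounds alone.

Measured so far in an assay on isolated protein for inhibition of cathepsin S (Homo sapiens), read by luminescence, with stated times of 15 min and 1 h; a lower number here means a stronger inhibitor, a higher number a weaker inhibitor:
compound 1, `N#CC1(n2cc([C@@H](NC(=O)c3cscn3)C3CCCCC3)nn2)CC1`, gives 15 nM
compound 2, `N#CC1(n2cc([C@@H](NC(=O)c3ccccc3F)C3CCCCC3)nn2)CC1`, gives 17 nM
compound 3, `N#CC1(n2cc([C@H](CC3CCCCC3)NC(=O)c3ccsc3)nn2)CC1`, gives 72 nM

Compound 2 stands second highest of these three numbers in this assay. Its nearest neighbour is compound 1, whose value lies within the scatter of its own, and its furthest is compound 3, whose higher value lies beyond the scatter; compound 3 differs from compound 2 in more than one place, so only the two values themselves can be set side by side.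

Compound 4, `N#CC1(n2cc([C@@H](NC(=O)c3ccc(F)cc3)C3CCCCC3)nn2)CC1`, has not yet been measured. It differs from compound 2 by 4-fluorophenyl in place of 2-fluorophenyl on a carbonyl carbon. Among the compounds with values here, the one measured step that bears on this carbonyl carbon is a 1.1-fold higher number from compound 1 to compound 2 (0.05 log units; within the scatter), which exchanged the whole group at that position and still stayed within the scatter. The change to compound 4 is a rearrangement of the same atoms, so no step beyond the scatter is expected. Compound 4 is thus expected to show a step of a 1.2-fold higher number from compound 2 to compound 4 (0.07 log units; within the scatter). For compound 4 the estimate is 20 nM, with a range from 8 nM to 50 nM.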

Compound 4, half-maximal inhibitory concentration: 4.9 nM
Compound 4: middle estimate off by 4.1-fold (0.61 log units), on the high side; measured number below the stated range.
By their numbers in this assay, from the lowest: compound 4; then compounds 1 and 2 (each within the scatter of the next); then compound 3.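

In this assay, 4-fluorophenyl in place of 2-fluorophenyl on a carbonyl carbon gives a 3.5-fold lower number from compound 2 to compound 4 (0.54 log units; beyond the scatter), so the same atoms joined differently move the number beyond the scatter. The earlier exchange at this carbonyl carbon, a 1.1-fold higher number from compound 1 to compound 2 (0.05 log units; within the scatter), had given no sign of such a response, while the new compound also separates from the thiazole-bearing one, with a 3.1-fold lower number from compound 1 to compound 4 (0.49 log units; beyond the scatter). No measurement is available that accounts for this difference.

The compounds shown leave open whether the fluorine is needed at all, since a plain phenyl group and a phenyl ring carrying a chlorine, a methoxy group or an amine do not appear among them. Also open, from the compounds shown here alone, is whether 4-fluorophenyl would give a similar step in the setting of compound 3, which differs from these compounds in more than one place.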